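Adding one hydroxymethyl to a side chain

The compounds below may be only part of what the source reports. "The series", "measured", "known", "first", "only" and "open" are said of these compounds alone.

Compound 1 (`COc1ccc(S(=O)(=O)N(CCO[C@@H]2O[C@H](CO)[C@@H](O)[C@H](O)[C@H]2O)CC(=O)NO)cc1`): 20000 ug/mL 
Compound 2 (`COc1ccc(S(=O)(=O)N(CCO)CC(=O)NO)cc1`): 20000 ug/mL 

Both values come from a physicochemical assay for solubility (on this read-out higher numbers stand for higher solubility and lower numbers for lower solubility), and show compound 2 level with compound 1, with no gap beyond the scatter of repeated measurements.

Compound 3 (`COc1ccc(S(=O)(=O)N(CC(=O)NO)C[C@H](O)CO)cc1`) differs from compound 2 in one place (hydroxymethyl in place of hydrogen on a saturated chain carbon bound to an oxygen on a saturated carbon and a saturated chain carbon). A hydroxymethyl stands in place of hydrogen on a saturated chain carbon bound to an oxygen on a saturated carbon and a saturated chain carbon, so 2-hydroxyethyl becomes 2,3-dihydroxypropyl.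

Within the data shown here, no measured pair shows this change on its own, so there is no direct precedent for its size. In this assay the expected step (no change at the digits printed from compound 2 to compound 3 (within the scatter)) is none beyond the scatter, in either direction. The estimate for compound 3 is 20000 ug/mL (expected range 10000 ug/mL to 40000 ug/mL).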

Compound 3, solubility: 20000 ug/mL
For compound 3 middle estimate and measured number coincide at the digits printed; low and high end bracket the measured number.
By their numbers in this assay, from the lowest: compounds 1, 2 and 3 (each within the scatter of the next).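

In this assay, among these compounds, this is the first pair in which a single change can be read: a hydroxymethyl in place of hydrogen on a saturated chain carbon, turning 2-hydroxyethyl into 2,3-dihydroxypropyl, gives no change at the digits printed from compound 2 to compound 3 (within the scatter). The earlier compounds shown here offered no pair differing in one place, so the size of this change at this position could not be read until now. Nothing measured here offers an explanation for this result.

Still open, from the compounds shown here alone, is whether another group at this position, such as an amine, a carboxylic acid or a longer chain, would give a step beyond the scatter in this assay. The same hydroxymethyl change on a different core is also untested by these compounds, so this single step cannot be extended to other series.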